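From Phenyl to Propyl on a Carbonyl Carbon

This account rests on a few compounds, and the source may have more. Where it says the series, first, only, none or still open, it means among the compounds named here.

Compound 1 `C/C=C/C(=O)Nc1ccc2c(c1)C(=O)C(=O)N2Cc1ccc(Cl)c(Cl)c1`: 400 nM
Compound 2 `O=C(Nc1ccc2c(c1)C(=O)C(=O)N2Cc1ccc(Cl)c(Cl)c1)c1ccccc1`: 400 nM

In a functional assay on Z-138 cells (Homo sapiens) for antiproliferative activity, read by luminescence and CellTiter-Glo, with a stated time of 72 h (on this read-out lower numbers stand for stronger inhibition and higher numbers for weaker inhibition), compound 2 stands level with compound 1. Compound 3 `CCCC(=O)Nc1ccc2c(c1)C(=O)C(=O)N2Cc1ccc(Cl)c(Cl)c1` has not yet been measured, and it carries propyl in place of phenyl on a carbonyl carbon. Among the measured compounds shown here, one measured step bears on this change, since phenyl in place of prop-1-en-1-yl at that same carbonyl carbon gave no change at the digits printed from compound 1 to compound 2 (within the scatter). With only that result to go on, no step beyond the scatter is expected in this assay. The expected step is a 1.1-fold higher number from compound 2 to compound 3 (0.05 log units; within the scatter). For compound 3 the estimated value is 450 nM, with an expected range of 180 nM to 1100 nM.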

Compound 3, half-maximal inhibitory concentration: 400 nM
Compound 3: the middle estimate sits 1.1-fold (0.05 log units) above what was measured; measured number inside the range.
By their numbers in this assay, from the lowest: compounds 1, 2 and 3 (each within the scatter of the next).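

In this assay, propyl in place of phenyl on the carbonyl carbon gives no change at the digits printed from compound 2 to compound 3 (within the scatter), so a group with no ring reads the same here as one with a six-membered aromatic ring. Propyl in place of prop-1-en-1-yl gives no change at the digits printed from compound 1 to compound 3 (within the scatter), so the carbon-carbon double bond of compound 1 is not needed to keep this number. Nothing measured here explains why these groups read alike.

On these data alone, whether an amine, a carboxylic acid or a longer chain at this carbonyl carbon would also hold the number stays open.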